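Aryl exchange on the five-membered ring: compound 1 to compound 3

The source may report more compounds than this note shows. Statements on the series, on what has been measured and on what is new or still open speak of the compounds shown alone.

The series in hand consists of compound 1 `COc1cncc(-c2c(C)nn(-c3nc(-c4ccc(Cl)c(Cl)c4)c(SC(C)C)s3)c2C(=O)O)c1` and compound 2 `Cc1c(-c2cc(Cl)cc(Cl)c2)c(C(=O)O)nn1-c1nc(-c2ccncc2)c(SC(C)C)s1`, with compound 3 `Cc1nn(-c2nc(-c3ccc(Cl)c(Cl)c3)c(SC(C)C)s2)c(C(=O)O)c1-c1cccc(Cl)c1` still to be measured. Among the measured compounds shown here, in a functional assay on BJAB cells (Homo sapiens) for antiproliferative activity, with a stated time of 4 days (a lower number here means that less compound is needed, a higher number that more compound is needed for the effect), compound 1 gives 21000 nM, the only number reported, so compound 1 stands alone in this assay as the one compound with a measured concentration. Compound 2 is reported as "not active" (no number reported) in this assay, without a number. For the measured compounds named here, neither result points to strong activity, and no pair of measured compounds differing in a single place is available, so no measured step tells how one change moves the read-out.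

Compound 3 differs from compound 1 in one place: 3-chlorophenyl in place of 5-methoxypyridin-3-yl on an aromatic carbon. Going by the values given here, with no measured step to rest on, the expectation is that the step of a 1.4-fold lower number from compound 1 to compound 3 (0.15 log units; within the scatter) remains within the usual scatter, in either direction, since compound 1 at 21000 nM is the only anchor. Compound 3 is accordingly expected to give 15000 nM in this assay, with a range from 4000 nM to 60000 nM, and with a real chance that only a lack of activity is reported.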

Compound 3, half-maximal effective concentration: 13600 nM
The estimate for compound 3 lay 1.1-fold (0.04 log units) above the measured number; measured number inside the range.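

In this assay, among the compounds shown here, 3-chlorophenyl in place of 5-methoxypyridin-3-yl, on the aromatic carbon next to the ring atom that bears a carboxy group, gives a 1.5-fold lower number from compound 1 to compound 3 (0.19 log units; within the scatter) as the only single-place step. This position therefore accepts an exchange of a pyridine ring carrying a methoxy group for a carbon-only aromatic ring carrying a chlorine with no change beyond the scatter, even though the group that enters has no hydrogen-bond acceptors and the group that leaves has them. No supporting measurement bears on this result, so the step stands as an observation without an explanation.

Still open, from the compounds shown here alone, is whether any group on this aromatic carbon can move the number beyond the scatter, which an aminomethyl group, a morpholine ring or an unsubstituted phenyl would help to test. Equally open, going by these compounds, is how much the neighbouring carboxy group contributes, which a primary amide or a tetrazole in its place on the core of compound 3 would address.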